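This account rests on a few compounds, and the source may have more. Where it says the series, first, only, none or still open, it means among the compounds named here.

Measured compounds:
compound 1, `CC1(Nc2ccc(NC(=O)c3cc(Cl)ccc3O)c(Cl)c2)CCCC1`: 157000 nM
compound 2, `CCN(CC)c1ccc(NC(=O)c2cc(Cl)ccc2O)c(Cl)c1`: 55500 nM
compound 3, `CC1(ON(c2ccc(NC(=O)c3cc(Cl)ccc3O)c(Cl)c2)C2(C)CCCC2)CCCC1`: 18000 nM

In an ADME assay on A549 cells (Homo sapiens) for cytotoxicity, read by resazurin assay, with a stated time of 48 h (on this read-out lower numbers stand for higher toxicity in this test and higher numbers for lower toxicity in this test), compound 1 stands highest of the three numbers. Its nearest neighbour is compound 2, reached by a 2.8-fold lower number from compound 1 to compound 2 (0.45 log units; beyond the scatter); the furthest is compound 3, reached by an 8.7-fold lower number from compound 1 to compound 3 (0.94 log units; beyond the scatter). Both changes away from compound 1 therefore gave lower numbers, one modest and one larger.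

Compound 4, `O=C(Nc1ccc(NCc2cc(F)cc(Cl)c2)cc1Cl)c1cc(Cl)ccc1O`, is yet to be measured in this assay. It differs from compound 1 in one place: 3-chloro-5-fluorobenzyl in place of 1-methylcyclopentyl on a nitrogen on an aromatic ring. For the measured compounds named here, no measured step matches this exchange exactly. The step from compound 1 to compound 2 is the closest comparison, since it also replaces the 1-methylcyclopentyl group on that nitrogen with a different substituent, and it lowered the number modestly. The step from compound 1 to compound 3 alters the same nitrogen in a different way and also lowered the number. On this basis the number for compound 4 is expected to move downward from compound 1, most likely by a modest amount, a 3.1-fold lower number from compound 1 to compound 4 (0.50 log units; beyond the scatter), though a result within the scatter cannot be excluded. Compound 4 is accordingly estimated at 50000 nM in this assay, with a range from 15000 nM to 160000 nM.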

Compound 4, half-maximal cytotoxic concentration: 11100 nM
Estimate against measurement, compound 4: 4.5-fold (0.65 log units) above; the whole stated range lies above it.
By their numbers in this assay, from the lowest: compounds 4 and 3 (each within the scatter of the next); then compound 2; then compound 1.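

For the compounds shown here, putting 3-chloro-5-fluorobenzyl in place of 1-methylcyclopentyl on a nitrogen on an aromatic ring gave a 14-fold lower number from compound 1 to compound 4 (1.15 log units; beyond the scatter) in this assay, and this is the only step from compound 1 that counts as large, the other two being modest. Going by these compounds alone, it shows that exchanging the single group on this nitrogen, with a six-membered aromatic ring of carbon entering and a five-membered non-aromatic ring leaving, can shift the number substantially without a second group being placed on that nitrogen, as happens in compound 2 and compound 3. Nothing measured here accounts for the size of this step.

The compounds shown leave open whether the step belongs to the aromatic ring of the benzyl group or to the chlorine and fluorine it carries, a question that an unsubstituted benzyl group on the same nitrogen would address. They also leave open how a saturated group of similar size, such as cyclohexylmethyl, would behave at this position, which would help separate the effect of the aromatic ring from that of the larger group.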